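A few compounds are considered here, and "the series" means these few. Any claim that something is new, unique, unknown or untested is made for them only; others in the source may bear on it.

In a functional assay on MGC-803 cells (Homo sapiens) for cytotoxicity, read by MTT assay, with a stated time of 72 h (a lower number here means a stronger inhibitor, a higher number a weaker inhibitor), two compounds sharing one core have been measured so far. Compound 1 `COc1ccc(C=C2C(=O)N(c3ccc(Cl)cc3)N(c3ccc(Cl)cc3)C2=O)cc1` gives > 128000 nM, which is a limit of the assay and not a number. Among the measured compounds shown here, compound 2 `COc1cccc(C=C2C(=O)N(c3ccc(Cl)cc3)N(c3ccc(Cl)cc3)C2=O)c1` gives 26600 nM, the only true number available.

Compound 3 `O=C1C(=Cc2ccco2)C(=O)N(c2ccc(Cl)cc2)N1c1ccc(Cl)cc1` carries furan-2-yl in place of 3-methoxyphenyl on a double-bonded chain carbon bound to a double-bonded ring carbon. For the measured compounds named here, the one measured step, an at least 4.8-fold lower number from compound 1 to compound 2 (0.68 log units; beyond the scatter), took place at this same carbon and rests on (the limit of > 128000 nM in this assay, at which 1 of the 2 values shown sits). It shows that a change here can move the number, but it swapped one methoxyphenyl for another, so it gives no direction for a new ring. The expected change, a 1.1-fold higher number from compound 2 to compound 3 (0.05 log units; within the scatter), is therefore no clear step beyond the scatter, with wide uncertainty. For compound 3 the estimated value is 30000 nM, with an expected range from 7000 nM to 110000 nM.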

Compound 3, half-maximal inhibitory concentration: 12800 nM
Compound 3: middle estimate off by 2.3-fold (0.37 log units), on the high side; the measured number falls inside the stated range.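

In this assay, the ring on this carbon need not be a methoxyphenyl at all. Furan-2-yl, with fewer heavy atoms than 3-methoxyphenyl, brings a 2.1-fold lower number from compound 2 to compound 3 (0.32 log units; beyond the scatter), the first step here that replaces the ring itself rather than moving the methoxy group around it. Set against 4-methoxyphenyl, the furan-2-yl change brings an at least 10-fold lower number from compound 1 to compound 3 (1.00 log units; beyond the scatter), but this step has only a bound and no exact size, since compound 1 is a limit and not a number: the limit of > 128000 nM in this assay, at which 1 of the 3 values shown sits.

With a single furan-2-yl among the compounds shown, the lower number cannot be assigned to the five-membered ring itself or to the oxygen within it, and a thiophene ring at this carbon would help to separate the two. On these data alone, how a phenyl ring bearing an amine or a carboxylic acid would read here also stays open.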